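The compounds below may be only part of what the source reports. "The series", "measured", "known", "first", "only" and "open" are said of these compounds alone.

Compound 1 `CNC(=O)CC1CCc2cc(OC)c(OC)cc21` is a small amide built on a shared core, and in a functional assay on the whole organism (strain Wistar) for inhibition, with Rattus norvegicus as the target, read by paw edema, with stated times of 60 min and 4 h, at a dose of 100 mg/kg by the oral route (a lower number here means less inhibition, a higher number more inhibition at the dose given (going by the name of the read-out)), compound 1 gives 29.7%. Among the three measured compounds it stands second highest. Compound 2 `COc1cc2c(cc1OC)C(CC(=O)N(C)C)CC2` gives 35.9%, and compound 3 `CCCCNC(=O)CC1CCc2cc(OC)c(OC)cc21` gives 25%. The step of a number 6.2 percentage points higher from compound 1 to compound 2 (within the scatter) and the step of a number 4.7 percentage points lower from compound 1 to compound 3 (within the scatter) both stay within the scatter, whereas the step of a number 10.9 percentage points lower from compound 2 to compound 3 (beyond the scatter) reaches beyond it, though only modestly.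

Compound 4 `CCCCCCNC(=O)CC1CCc2cc(OC)c(OC)cc21` has not yet been measured. It differs from compound 1 by pentyl in place of hydrogen on a saturated chain carbon bound to an amide-type nitrogen. The closest guide is the step of a number 4.7 percentage points lower from compound 1 to compound 3 (within the scatter), which also put a chain in place of hydrogen at the same place and produced no change beyond the scatter. A longer chain in compound 4 therefore gives little reason to expect a large move in this assay, and any drift would be expected to follow compound 3 downward. For compound 4 the estimate is 24%, with a range from 12% to 36%. The expected step of a number 5.7 percentage points lower from compound 1 to compound 4 (within the scatter) stays within the scatter.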

Compound 4, a percentage reported as inhibition, in the whole organism at one dose (the size of the read-out at that dose, not a potency): 42.1%
Estimate against measurement, compound 4: 18.1 percentage points below; the measured number lies above the stated range.
By their numbers in this assay, from the lowest: compounds 3, 1, 2 and 4 (each within the scatter of the next, the first and the last beyond it).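

With a long enough chain on the amide nitrogen, the number can rise in this assay: the hexyl chain gives a number 12.4 percentage points higher from compound 1 to compound 4 (beyond the scatter), and going from the butyl chain to the hexyl chain gives a number 17.1 percentage points higher from compound 3 to compound 4 (beyond the scatter). The number therefore does not follow chain length in one steady direction, as compound 3 goes against a simple rise with length, and the hexylamino and dimethylamino amides cannot be told apart, with a number 6.2 percentage points higher from compound 2 to compound 4 (within the scatter). No measurement shown here explains why the hexyl chain has this effect.

On these data alone, it remains open whether a chain longer than hexyl would hold, raise or lower the number, and whether octyl would continue the rise seen from butyl to hexyl. Also open, as far as these compounds go, is how a hexyl chain carrying an amine or a carboxylic acid would read.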